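Working notes on the series: compound 2 to compound 3

The compounds below may be only part of what the source reports. "The series", "measured", "known", "first", "only" and "open" are said of these compounds alone.

Measured so far:
compound 1 `COc1cc(NC(C)CCCNC(=O)NC(c2ccccc2)c2ccccc2)c2ncccc2c1`: > 100000 nM
compound 2 `COc1cc(NC(C)CCCNC(=O)NCc2ccccc2)c2ncccc2c1`: 30000 nM

In a functional assay on NCI-H460 cells (Homo sapiens), read by MTT assay, with a stated time of 72 h (a lower number here means a stronger inhibitor, a higher number a weaker inhibitor), compound 1 gives > 100000 nM, which is a limit of the assay and not a number. In this assay compound 2 gives 30000 nM, the only number shown in the series so far. Going by the values given here, the one measured step is an at least 3.3-fold lower number from compound 1 to compound 2 (0.52 log units; beyond the scatter); it concerns the far end of the chain, away from the carbonyl, and is bounded by the limit of > 100000 nM in this assay, at which 1 of the 2 values shown sits.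

Compound 3 `COc1cc(NC(C)CCCNC(=O)n2nnc3ccccc32)c2ncccc2c1` differs from compound 2 by a group of 9 heavy atoms (6 carbon, 3 nitrogen; one five-membered aromatic ring with 3 hetero atoms, one six-membered aromatic ring of carbon only) in place of a group of 8 heavy atoms (7 carbon, 1 nitrogen; one six-membered aromatic ring of carbon only), on a carbonyl carbon. Among the compounds with values here, no measured step touches that carbonyl carbon, so the step from compound 1 to compound 2 gives no direct guide here; it shows only that changes at the terminal group can move this read-out by at least a modest amount. Within the data shown here, with no closer precedent, the expectation for compound 3 is a step of no change at the digits printed from compound 2 to compound 3 (within the scatter), that is, no change beyond the scatter, with a wide range on either side. Compound 3 is accordingly estimated at 30000 nM (7000 nM to 100000 nM).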

Compound 3, half-maximal inhibitory concentration: > 100000 nM
Compound 3: only a limit was reported; the forecaster's own chance of this, stated with the estimate: 35%; at least 3.3-fold (0.52 log units) between middle value and limit.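

At the carbonyl carbon, whose other neighbour is an amide-type nitrogen, the benzylamino group of compound 2 is not freely exchangeable: putting the group with a five-membered aromatic ring with 3 hetero atoms and a six-membered aromatic ring of carbon only in its place gives an at least 3.3-fold higher number from compound 2 to compound 3 (0.52 log units; beyond the scatter) in this assay. Compound 3 gives > 100000 nM, which is a limit of the assay and not a number. This is the first step shown at this position, and with it compound 2 is the only compound with a number, so neither terminal change shown keeps a measurable value and the full size of the step stays unknown: the limit of > 100000 nM in this assay, at which 2 of the 3 values shown sit.

The benzylamino group has 1 hydrogen-bond donor and 0 hydrogen-bond acceptors and the entering group has 0 and 3, but this single change alters the ring system and these counts together, so the compounds shown cannot separate them. From the compounds shown here alone, whether a simple anilino group or a morpholine on the same carbonyl carbon would keep a measurable value, or give a lower number than compound 2, remains open.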